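The source may report more compounds than this note shows. Statements on the series, on what has been measured and on what is new or still open speak of the compounds shown alone.

Compound 2 `C[C@@H]1CCCN1c1c(C#N)c2c(N)nccc2n1C` gives 2 nM in an assay on isolated protein for binding affinity to Leucine-rich repeat serine/threonine-protein kinase 2 variant G2019S (Homo sapiens), read by TR-FRET and LanthaScreen, with a stated time of 2 h (on this read-out higher numbers stand for weaker inhibition and lower numbers for stronger inhibition), the lowest of the three numbers recorded. Compound 1 `C[C@@H]1CCCN1c1c(C#N)c2c(N)nc(Nc3ccn(C)n3)cc2n1C` gives 13 nM in this assay, and compound 3 `C[C@@H]1CCCN1c1c(C(N)=O)c2c(N)ncnc2n1C` gives 154 nM, so both sit beyond the scatter above compound 2. Among the measured compounds shown here, the one measured step that differs in a single place is a 6.5-fold lower number from compound 1 to compound 2 (0.81 log units; beyond the scatter). Compound 4 `Cc1cn(C)nc1Nc1cc2c(c(N)n1)c(C#N)c(N1CCC[C@H]1C)n2C` has not been measured; it differs from compound 2 in that ((1,4-dimethyl-1H-pyrazol-3-yl)amino in place of hydrogen on an aromatic carbon), the same position at which compound 1 carries its (1-methyl-1H-pyrazol-3-yl)amino group, and it is the step from compound 1 to compound 2 that bears on it. Since removing that group from compound 1 lowered the number by a 6.5-fold lower number from compound 1 to compound 2 (0.81 log units; beyond the scatter), adding a closely related (1,4-dimethyl-1H-pyrazol-3-yl)amino group to compound 2 is expected to raise it by a similar, modest amount, so compound 4 is estimated at a 7.5-fold higher number from compound 2 to compound 4 (0.88 log units; beyond the scatter). Compound 4 is therefore expected to give 15 nM in this assay, within a range from 5 nM to 45 nM.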

Compound 4, inhibition constant: 75 nM
The estimate for compound 4 lay 5.0-fold (0.70 log units) below the measured number, and the stated range ends below it.
By their numbers in this assay, from the lowest: compound 2; then compound 1; then compound 4; then compound 3.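

In this assay, among the compounds shown here, the position on the aromatic carbon next to the ring nitrogen tolerates the (1,4-dimethyl-1H-pyrazol-3-yl)amino group far less well than the earlier compounds showed, with a 38-fold higher number from compound 2 to compound 4 (1.57 log units; beyond the scatter) as a large step. The new information lies in the pyrazole methyl: methyl in place of hydrogen on an aromatic carbon of the group gives a 5.8-fold higher number from compound 1 to compound 4 (0.76 log units; beyond the scatter), so a single methyl on the attached ring alters the reading beyond the scatter. No measurement given here explains this change.

On these data alone, it remains open whether an ethyl group or a chlorine atom in place of that methyl would shift the number in the same direction. Also open, as far as these compounds go, is how a plain amino group or a methoxy group would read at this position on the shared core.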